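The compounds below may be only part of what the source reports. "The series", "measured", "known", "first", "only" and "open" are said of these compounds alone.

Two compounds of the series have numbers in a functional assay on HEK293 cells for negative allosteric modulation of metabotropic glutamate receptor 5 (Homo sapiens), read by calcium flux, with a stated time of 20 min; on this read-out higher numbers stand for weaker inhibition and lower numbers for stronger inhibition. Compound 1 `O=C(c1ccccc1)N1CCn2nc(-c3ccc(F)cn3)cc2C1` carries an unsubstituted phenyl on the amide; in this assay compound 1 gives 164 nM. Compound 2 `Cc1cccc(C(=O)N2CCn3nc(-c4ccc(F)cn4)cc3C2)c1` carries a methyl on that ring; in this assay compound 2 gives 150 nM. For the measured compounds named here, the only step between measured compounds, a 1.1-fold lower number from compound 1 to compound 2 (0.04 log units; within the scatter), did not move the number beyond the scatter. On the two numbers compound 2 sits at the low end, but within the scatter of compound 1, so the two are not distinguished.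

Compound 3 `N#Cc1cccc(C(=O)N2CCn3nc(-c4ccc(F)cn4)cc3C2)c1` is the next member. It differs from compound 2 by cyano in place of methyl on an aromatic carbon. Going by the values given here, no measured step exchanges a methyl for a cyano; the one step that touches this position, a 1.1-fold lower number from compound 1 to compound 2 (0.04 log units; within the scatter), only shows that a methyl at this place leaves the number where it was. Among the compounds with values here, a cyano is a different group, and the series holds no step of the same kind. The expectation for compound 3 is a step of a 1.2-fold higher number from compound 2 to compound 3 (0.08 log units; within the scatter) in this assay, most likely within the scatter. Compound 3 is estimated at 180 nM, with a range from 60 nM to 550 nM.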

Compound 3, half-maximal inhibitory concentration: > 10000 nM
Compound 3: a limit, no number (the forecaster's own chance of this, stated with the estimate: 5%); at least 55-fold (1.74 log units) between middle value and limit.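

In this assay compound 3 gives > 10000 nM, which is a limit of the assay and not a number. Cyano in place of methyl gives an at least 66-fold higher number from compound 2 to compound 3 (1.82 log units; beyond the scatter), and cyano in place of hydrogen gives an at least 60-fold higher number from compound 1 to compound 3 (1.78 log units; beyond the scatter), so this place on the aromatic ring, where the methyl of compound 2 left the number within the scatter of compound 1, is not open to every group, a point the first two compounds could not show. Both steps are read against that limit, so they give no exact size for the change: the limit of > 10000 nM in this assay, at which 1 of the 3 values shown sits.

The compounds shown hold only hydrogen, methyl and cyano at this place, and compound 3 is the only nitrile among them, so it stays open whether the large step belongs to cyano alone or would also come with a chlorine atom, a methoxy group or a primary amide in the same place. Also open, going by these compounds, is whether a cyano elsewhere on this ring, or on the core of compound 1 with another amide partner, would give a step of the same kind.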